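A few compounds are considered here, and "the series" means these few. Any claim that something is new, unique, unknown or untested is made for them only; others in the source may bear on it.

Compound 1 `COc1ccc(Cn2cc(/C=N\NC(=O)c3c[nH]c4ccccc34)c3cc(OC)ccc32)cc1`, compound 2 `COc1ccc(Cn2cc(/C=N\NC(=O)c3c[nH]c4ccc(Br)cc34)c3cc(OC)ccc32)cc1` and compound 3 `COc1ccc(Cn2cc(/C=N\NC(=O)c3c[nH]c4ccc(Br)cc34)c3ccc(F)cc32)cc1` share a hydrazone linking an indole carboxamide to a benzylated indole, and all three were tested in a functional assay on MIA PaCa-2 cells (Homo sapiens) for cytotoxicity; on this read-out higher numbers stand for weaker inhibition and lower numbers for stronger inhibition. Compound 1 gives 30500 nM, compound 2 gives 44500 nM and compound 3 gives 45500 nM. Going from compound 2 to compound 1 the change is hydrogen in place of bromo on an aromatic carbon, and the step is a 1.5-fold lower number from compound 2 to compound 1 (0.16 log units; within the scatter). Compound 3 and compound 2 differ in their cores, and that difference between the two cores is not broken down here; their two values in this assay lie close together. Compound 4 `COc1ccc(Cn2cc(/C=N\NC(=O)c3c[nH]c4ccccc34)c3ccc(F)cc32)cc1` has not yet been measured. Its relation to compound 3 is the same change as that from compound 2 to compound 1, namely (hydrogen in place of bromo on an aromatic carbon), at the same place on the fused six-membered carbon ring. Among the measured compounds shown here, the step from compound 3 to compound 4 in this assay is expected to be a 1.5-fold lower number from compound 3 to compound 4 (0.17 log units; within the scatter), because the one earlier instance of this change gave a 1.5-fold lower number from compound 2 to compound 1 (0.16 log units; within the scatter). On that basis compound 4 is estimated at 31000 nM, with a range from 15000 nM to 62000 nM.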

Compound 4, half-maximal inhibitory concentration: 43300 nM
The estimate for compound 4 lay 1.4-fold (0.15 log units) below the measured number; measured number inside the range.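

Replacing 5-bromo-1H-indol-3-yl with 1H-indol-3-yl on the core of compound 3 gives, in this assay, a 1.1-fold lower number from compound 3 to compound 4 (0.02 log units; within the scatter). Set beside the earlier instance on the core of compound 2, the change carries from one core to the other with no gap that can be told from scatter: the same change on two cores in this assay, a 1.5-fold lower number (0.16 log units; within the scatter) from compound 2 to compound 1 and a 1.1-fold lower number (0.02 log units; within the scatter) from compound 3 to compound 4, 1.4-fold (0.14 log units) apart, within the scatter of two such steps This shows only that the step stays small on both of these cores; it does not show that the change has any real effect on either core, as neither step rises above the scatter, and two pairs give no rule for other cores.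

The compounds shown leave open whether another group at this place on the indole, such as an amine or a carboxylic acid, would shift the number beyond the scatter. They also leave open whether the exchange of bromo for hydrogen would stay this small on a core carrying an amine in place of the methoxy group on the benzyl ring.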